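The source may report more compounds than this note shows. Statements on the series, on what has been measured and on what is new or still open speak of the compounds shown alone.

Compound 1 `Cc1nc(-c2ccccc2)c(C(=O)N2CCN(c3ccccc3Cl)CC2)o1` is the reference point of this small set. In a functional assay on HL-60 cells (Homo sapiens) for inhibition, read by MTT assay, with a stated time of 72 h (a lower number here means a stronger inhibitor, a higher number a weaker inhibitor), compound 1 gives 124 nM, and this is the only numerical result in the set. Compound 2 `CCCc1nc(-c2ccc(OC)cc2)c(C(=O)N2CCN(c3cccc(Cl)c3)CC2)o1` was also tested, and in this assay compound 2 is reported as "not active" (no number reported) without a number. Compound 2 differs from compound 1 in several places at once, so the two results cannot be traced to any single change.

Compound 3 `Cc1nc(-c2ccccc2)c(C(=O)N2CCN(c3cccc(F)c3)CC2)o1` is the new compound. It differs from compound 1 in one place: 3-fluorophenyl in place of 2-chlorophenyl on an amine nitrogen in a ring. Among the compounds with values here, no pair of measured compounds shows what such a swap does in this assay, and the result for compound 2 gives only a hint that a change on the ring attached to the amine nitrogen can matter. A step of moderate size, toward weaker inhibition, is therefore expected, while a result within the scatter would not be surprising. The step from compound 1 to compound 3 is expected to be a 2.4-fold higher number from compound 1 to compound 3 (0.38 log units; beyond the scatter). In this assay compound 3 is estimated at 300 nM, with a likely range from 100 nM to 1500 nM.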

Compound 3, half-maximal inhibitory concentration: 45 nM
Beside the measured number, compound 3's estimate is 6.7-fold (0.82 log units) above it, and the stated range ends above it.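

In this assay, within the data shown here, putting 3-fluorophenyl in place of 2-chlorophenyl on the amine nitrogen in a ring gives a 2.8-fold lower number from compound 1 to compound 3 (0.44 log units; beyond the scatter), the first step in this set that can be traced to a single change. It shows that this group is a place where a change alone can move the number beyond the usual scatter, and that here the move is toward stronger inhibition, so 2-chlorophenyl is not required for activity in the core of compound 1. Nothing shown explains why the number moves, and the swap alters both the halogen and its location on the phenyl ring together, so the step belongs to the whole exchange and not to either part.

Going by these compounds, what stays open is how much of the step comes from fluorine replacing chlorine and how much from the new location, a question that 2-fluorophenyl on the same core could help to separate. Also open, on these data alone, is whether the halogen matters at all, which plain phenyl or a group of another kind, such as 3-methoxyphenyl, could test.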